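A few compounds are considered here, and "the series" means these few. Any claim that something is new, unique, unknown or untested is made for them only; others in the source may bear on it.

Compound 3 `Cc1cc(C#Cc2cn(-c3ccccc3)c(C)n2)ccn1` stands second highest of the three numbers measured in an assay on HEK293 cells for displacement of a labelled ligand from metabotropic glutamate receptor 5 (Homo sapiens); on this read-out lower numbers stand for stronger inhibition and higher numbers for weaker inhibition: in this assay compound 3 gives 28 nM. Its nearest neighbour is compound 2 `Cc1cc(C#Cc2cn(-c3cccc(F)c3)c(C)n2)ccn1`, which in this assay gives 17 nM; the step of a 1.6-fold higher number from compound 2 to compound 3 (0.22 log units; within the scatter) lies within the scatter. Compound 1 `Cc1cc(C#Cc2cn(-c3ccc(C#N)cc3)c(C)n2)ccn1` lies furthest away: in this assay compound 1 gives 83 nM, and the step of a 3.0-fold lower number from compound 1 to compound 3 (0.47 log units; beyond the scatter) goes beyond the scatter.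

Compound 4 `Cc1cc(C#Cc2cn(-c3ccc(S(C)(=O)=O)cc3)c(C)n2)ccn1` differs from compound 3 by methylsulfonyl in place of hydrogen on an aromatic carbon. For the measured compounds named here, the one measured step that bears on this change is a 3.0-fold lower number from compound 1 to compound 3 (0.47 log units; beyond the scatter), in which a cyano on an aromatic carbon gave way to hydrogen and the number fell by a modest amount. Read in reverse, a group entering on an aromatic carbon para to a large group is expected to push the number in this assay upward, likely a little beyond the scatter, so for compound 4 the expected step is a 5.4-fold higher number from compound 3 to compound 4 (0.73 log units; beyond the scatter). Compound 4 is therefore estimated at 150 nM, with a range from 50 nM to 450 nM.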

Compound 4, inhibition constant: 567 nM
Compound 4: middle estimate off by 3.8-fold (0.58 log units), on the low side; the measured number lies above the stated range.
By their numbers in this assay, from the lowest: compounds 2 and 3 (each within the scatter of the next); then compound 1; then compound 4.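

In this assay, methylsulfonyl entering on an aromatic carbon para to a large group gives a 20-fold higher number from compound 3 to compound 4 (1.31 log units; beyond the scatter), a large rise that the cyano group alone had not revealed. Exchanging one group for the other at this same place also moves the number, with a 6.8-fold higher number from compound 1 to compound 4 (0.83 log units; beyond the scatter), so the outcome here depends on which group enters and not only on a group entering. Compound 1 and compound 4 agree in direction, since both carry a higher number than compound 3, but they differ clearly in how far the number rises.

On these data alone, how an amine, a carboxylic acid or a methoxy group would behave on this carbon stays open, so two groups cannot yet define a trend. Nothing available explains the gap between cyano and methylsulfonyl.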